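Cyclopropyl in Place of Isopropyl on the Pyrazole Nitrogen

The compounds below may be only part of what the source reports. "The series", "measured", "known", "first", "only" and "open" are said of these compounds alone.

Measured so far:
compound 1, `CCn1cc(-c2n[nH]c3cc(-c4cc(C(=O)Nc5cccc(C(F)(F)F)c5)ccc4C)ccc23)cn1`: 2.6 nM
compound 2, `Cc1ccc(C(=O)Nc2cccc(C(F)(F)F)c2)cc1-c1ccc2c(-c3cnn(C(C)C)c3)n[nH]c2c1`: 7.7 nM

In an assay on isolated protein for inhibition of Discoidin domain-containing receptor 2 (Homo sapiens), read by ELISA, with a stated time of 60 min (on this read-out higher numbers stand for weaker inhibition and lower numbers for stronger inhibition), compound 1 gives 2.6 nM, while compound 2 gives 7.7 nM, the higher of the two numbers. For the measured compounds named here, the one measured step, a 3.0-fold higher number from compound 1 to compound 2 (0.47 log units; beyond the scatter), shows that a larger group on this nitrogen costs a modest amount of inhibition.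

Compound 3, `Cc1ccc(C(=O)Nc2cccc(C(F)(F)F)c2)cc1-c1ccc2c(-c3cnn(C4CC4)c3)n[nH]c2c1`, differs from compound 2 by cyclopropyl in place of isopropyl on an aromatic nitrogen. Going by the values given here, no measured step matches this change directly; the step from compound 1 to compound 2 bears on it only in showing that this assay responds modestly to the shape of the group here, and cyclopropyl keeps the same count of heavy atoms as isopropyl. A change within the scatter, perhaps a slight lowering, is expected. Compound 3 is therefore estimated to give 5 nM in this assay, within a range from 2 nM to 14 nM. That corresponds to an expected step of a 1.5-fold lower number from compound 2 to compound 3 (0.19 log units; within the scatter).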

Compound 3, half-maximal inhibitory concentration: 3.2 nM
Compound 3: middle estimate off by 1.6-fold (0.19 log units), on the high side; measured number inside the range.
By their numbers in this assay, from the lowest: compounds 1 and 3 (each within the scatter of the next); then compound 2.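

In this assay, changing isopropyl to cyclopropyl on the aromatic nitrogen gives a 2.4-fold lower number from compound 2 to compound 3 (0.38 log units; beyond the scatter) even though both groups have 3 heavy atoms, so heavy-atom count alone does not set the number at this position. Changing ethyl to cyclopropyl gives a 1.2-fold higher number from compound 1 to compound 3 (0.09 log units; within the scatter), which leaves compound 1 and compound 3 indistinguishable in this assay and makes compound 2, with isopropyl, the only one of the three that stands apart. Nothing measured here explains why isopropyl and cyclopropyl differ.

On these data alone, it remains open whether a cyclobutyl ring, a tert-butyl group or a longer chain such as propyl would sit with ethyl and cyclopropyl or with isopropyl. As far as these compounds go, the effect of an amine or a hydroxyl group carried on a chain at this nitrogen also remains unknown.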